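Changing the aryl group on the amide of compound 2

The compounds below may be only part of what the source reports. "The series", "measured", "known", "first", "only" and "open" are said of these compounds alone.

In a functional assay on A549 cells (Homo sapiens) for inhibition, read by CCK-8 assay, with a stated time of 72 h, tested at 10 uM (a higher number here means more inhibition of growth at the concentration tested, a lower number less inhibition of growth), compound 1 `Cc1cccc(NC(=O)C2(C(=O)Nc3ccc(Nc4ncc5cc(C(=O)N(C)C)n(C6CCCC6)c5n4)cc3)CC2)c1` gives 86.1% and compound 2 `CN(C)C(=O)c1cc2cnc(Nc3ccc(NC(=O)C4(C(=O)Nc5ccc(Cl)c(C(F)(F)F)c5)CC4)cc3)nc2n1C1CCCC1` gives 88.1%. These two numbers lie within the scatter of each other, so compound 2 stands level with compound 1, and both show strong inhibition of growth.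

Compound 3 `CN(C)C(=O)c1cc2cnc(Nc3ccc(NC(=O)C4(C(=O)Nc5ccc(O)cc5)CC4)cc3)nc2n1C1CCCC1` keeps the rest of compound 2 and changes one group: 4-hydroxyphenyl in place of 4-chloro-3-(trifluoromethyl)phenyl on an amide-type nitrogen.

Among the compounds with values here, only one measured step bears on this change. It swapped the group on an amide-type nitrogen too, and it is a number 2 percentage points higher from compound 1 to compound 2 (within the scatter). That small step suggests some tolerance for change at this place, but neither measured compound carries a hydroxyl group, so the data do not cover the new group directly. A modest loss in this assay therefore seems a cautious expectation, though no loss at all remains possible. The estimated change is a number 10.1 percentage points lower from compound 2 to compound 3 (beyond the scatter). For compound 3 the expected value is 78%, within an estimated range from 60% to 90%.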

Compound 3, percent growth inhibition at one concentration: 94.4%
For compound 3 the middle estimate is 16.4 percentage points below the measured one; measured number outside the range, above it.
By their numbers in this assay, from the lowest: compounds 1, 2 and 3 (each within the scatter of the next).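

In this assay the new group gives a number 6.3 percentage points higher from compound 2 to compound 3 (within the scatter) and also a number 8.3 percentage points higher from compound 1 to compound 3 (within the scatter) so the three aryl groups on this amide-type nitrogen stand level with one another. Compounds 1 and 2 carried only 3-methylphenyl and 4-chloro-3-(trifluoromethyl)phenyl, neither of which has a hydrogen-bond donor or acceptor. Compound 3 extends the tolerance seen so far to a 4-hydroxyphenyl group, which has one of each and fewer heavy atoms than the group it replaces, while growth inhibition stays strong; no measurement shown here accounts for this tolerance.

The compounds shown leave open whether the hydroxyl hydrogen matters at all, which a 4-methoxyphenyl group could test, and whether an amine or a carboxylic acid in the same spot, or a cyclohexyl group in place of the aromatic ring, would be accepted as well. They also leave open how these three compounds would separate at lower concentrations, since a reading at one concentration cannot show differences that lie within the scatter here.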